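Chloro on the sulfonyl phenyl: a step from compound 1

This account rests on a few compounds, and the source may have more. Where it says the series, first, only, none or still open, it means among the compounds named here.

Measured compounds and values:
- compound 1, `O=C(Nc1cnn(-c2ccccc2)c1)c1cccc(NS(=O)(=O)c2ccccc2)c1`: 4320 nM
- compound 2, `COc1ccc(-n2cc(NC(=O)c3cccc(NS(=O)(=O)c4ccccc4)c3)cn2)cc1`: 18700 nM
- compound 3, `COc1cccc(-n2cc(NC(=O)c3cccc(NS(=O)(=O)c4ccccc4)c3)cn2)c1`: 16700 nM

In a functional assay on MCF7 cells (Homo sapiens) for inhibition, read by MTT assay, with a stated time of 48 h (on this read-out higher numbers stand for weaker inhibition and lower numbers for stronger inhibition), compound 1 gives the lowest number of the three. Its nearest neighbour is compound 3, a 3.9-fold higher number from compound 1 to compound 3 (0.59 log units; beyond the scatter); the furthest is compound 2, a 4.3-fold higher number from compound 1 to compound 2 (0.64 log units; beyond the scatter). Both of those steps put a methoxy on the phenyl that sits on the aromatic nitrogen of the shared core, and both move the number up by a modest amount. Compound 2 and compound 3 sit within the scatter of each other, a 1.1-fold lower number from compound 2 to compound 3 (0.05 log units; within the scatter).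

Compound 4, `O=C(Nc1cnn(-c2ccccc2)c1)c1cccc(NS(=O)(=O)c2ccc(Cl)cc2)c1`, differs from compound 1 at a different place: chloro in place of hydrogen on an aromatic carbon. For the measured compounds named here, no measured step touches the phenylsulfonyl part, so the methoxy steps do not bear on this change directly; they only show that small additions elsewhere on this core have cost activity. With nothing to the point, no step beyond the scatter is expected in this assay for compound 4, a 1.0-fold higher number from compound 1 to compound 4 (0.02 log units; within the scatter). Compound 4 is therefore estimated at 4500 nM, with a range from 1500 nM to 14000 nM.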

Compound 4, half-maximal inhibitory concentration: 3130 nM
The estimate for compound 4 lay 1.4-fold (0.16 log units) above the measured number, and the stated range covers the measured number.
By their numbers in this assay, from the lowest: compounds 4 and 1 (each within the scatter of the next); then compounds 3 and 2 (each within the scatter of the next).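

In this assay, chloro in place of hydrogen on the phenylsulfonyl part, at the aromatic carbon para to a large group, gives no step beyond the scatter (a 1.4-fold lower number from compound 1 to compound 4 (0.14 log units; within the scatter)). This position therefore accepts one added chlorine atom with no readable change, whereas each methoxy addition on the phenyl on the aromatic nitrogen gave a step beyond the scatter (a 4.3-fold higher number from compound 1 to compound 2 (0.64 log units; beyond the scatter); a 3.9-fold higher number from compound 1 to compound 3 (0.59 log units; beyond the scatter)), though those steps differ from this one in both the group and the place. No measurement at hand explains this contrast.

On these data alone, whether an amine, a carboxylic acid or a methoxy at this same position would also leave the number within the scatter of compound 1 remains open. Also open, as far as these compounds go, is how chloro on the phenyl on the aromatic nitrogen would compare with the methoxy steps there.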